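The source may hold more compounds than are shown below. What is called first, only, known or untested is meant among the compounds shown, and "the series" means these compounds.

Series notes. Going by the values given here, compound 1 `COc1cc(C(=O)c2sc(-c3ccc(Br)cc3)cc2N)cc(OC)c1OC` gives 100 nM in a functional assay on L1210 cells (Mus musculus) for antiproliferative activity (on this read-out lower numbers stand for stronger inhibition and higher numbers for weaker inhibition), the second highest of the three numbers so far. Compound 2 `COc1ccc(-c2cc(N)c(C(=O)c3cc(OC)c(OC)c(OC)c3)s2)cc1OC` gives 40 nM in this assay; the step is a 2.5-fold lower number from compound 1 to compound 2 (0.40 log units; beyond the scatter). Compound 3 `COc1cc(C(=O)c2sc(-c3ccc(I)cc3)cc2N)cc(OC)c1OC` gives 400 nM in this assay; here the step is a 4.0-fold higher number from compound 1 to compound 3 (0.60 log units; beyond the scatter), and between the other two it is a 10-fold higher number from compound 2 to compound 3 (1.00 log units; beyond the scatter). Compound 4 `COc1cc(C(=O)c2sc(-c3ccc(C(F)(F)F)cc3)cc2N)cc(OC)c1OC` is not yet measured and differs from compound 1 thus: trifluoromethyl in place of bromo on an aromatic carbon. Among the compounds with values here, no measured step covers trifluoromethyl at all; the only change at the same place is a 4.0-fold higher number from compound 1 to compound 3 (0.60 log units; beyond the scatter), which was modest and went upward, so only a modest shift, or none beyond the scatter, is anticipated in this assay. Compound 4 is therefore expected at about 150 nM, range 50 nM to 500 nM, an expected step of a 1.5-fold higher number from compound 1 to compound 4 (0.18 log units; within the scatter).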

Compound 4, half-maximal inhibitory concentration: 370 nM
For compound 4 the middle estimate is 2.5-fold (0.39 log units) below the measured one, within the range that was stated.
By their numbers in this assay, from the lowest: compound 2; then compound 1; then compounds 4 and 3 (each within the scatter of the next).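

Trifluoromethyl in place of bromo (a 3.7-fold higher number from compound 1 to compound 4 (0.57 log units; beyond the scatter)) moves the number in this assay upward, as iodo did, so two different replacements of bromo now point the same way. Trifluoromethyl and iodo cannot be told apart at this position (a 1.1-fold lower number from compound 3 to compound 4 (0.03 log units; within the scatter)), and the 3,4-dimethoxyphenyl group keeps its lead over the new group (a 9.3-fold higher number from compound 2 to compound 4 (0.97 log units; beyond the scatter)). No measured property of these groups is at hand to explain the result.

Going by these compounds alone, still open is whether a 4-methoxyphenyl group with its single methoxy would match compound 2. On these data alone, how chloro or an amine at this position would compare with bromo is also open.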